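Amine tail change in the series of compound 1

The source may report more compounds than this note shows. Statements on the series, on what has been measured and on what is new or still open speak of the compounds shown alone.

Compound 1 `COc1cc2c(Oc3ccc(NC(=O)c4cn(-c5ccccc5C)nn4)cc3F)ccnc2cc1OCCCN1CCCC1` carries a pyrrolidin-1-yl group at the end of its chain and a 2-methylphenyl group on an aromatic nitrogen. Going by the values given here, in a functional assay on NCI-H460 cells (Homo sapiens) for cytotoxicity, read by MTT assay, with a stated time of 72 h (a lower number here means a stronger inhibitor, a higher number a weaker inhibitor), compound 1 gives 1260 nM, the highest of the two numbers so far. Among the compounds with values here, its nearest neighbour is compound 2 `COc1cc2c(Oc3ccc(NC(=O)c4cn(-c5ccc(Br)cc5)nn4)cc3F)ccnc2cc1OCCCN1CCCC1`, which in this assay gives 200 nM; the one measured step, a 6.3-fold lower number from compound 1 to compound 2 (0.80 log units; beyond the scatter), concerns the aryl group on the aromatic nitrogen and nothing else.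

Compound 3 `COc1cc2c(Oc3ccc(NC(=O)c4cn(-c5ccccc5C)nn4)cc3F)ccnc2cc1OCCCN1CCN(C)CC1` keeps the 2-methylphenyl group of compound 1 and differs from it only at the chain end: 4-methylpiperazin-1-yl in place of pyrrolidin-1-yl on a saturated chain carbon, three bonds along the chain from an oxygen on an aromatic ring. Within the data shown here, no measured step touches this part of the molecule, so the step from compound 1 to compound 2 does not bear on the change and no direction can be read from it. With the group that was varied in the measured pair left unchanged, the expectation for compound 3 is a step within the scatter, a 1.1-fold lower number from compound 1 to compound 3 (0.06 log units; within the scatter), in either direction. Compound 3 is therefore estimated at 1100 nM in this assay, with a range from 400 nM to 3000 nM; the width reflects that the chain end has not been varied among the measured compounds.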

Compound 3, half-maximal inhibitory concentration: 3650 nM
Compound 3: middle estimate off by 3.3-fold (0.52 log units), on the low side; measured number above the stated range.
By their numbers in this assay, from the lowest: compound 2; then compound 1; then compound 3.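

The chain end is not a silent position: with the 2-methylphenyl group held constant, 4-methylpiperazin-1-yl in place of pyrrolidin-1-yl gives, in this assay, a 2.9-fold higher number from compound 1 to compound 3 (0.46 log units; beyond the scatter). In this pair, the number therefore depends on the amine at the end of the chain as well as on the aryl group on the aromatic nitrogen, and pyrrolidin-1-yl gives the lower number. The change replaces a five-membered ring carrying 1 hetero atom with a six-membered ring carrying 2 hetero atoms, and this single pair cannot separate ring size from the added nitrogen or its methyl group, while no measurement available here accounts for the step.

Still open, as far as these compounds go, is whether the same amine change gives a step of similar direction and size when the 4-bromophenyl group of compound 2 replaces the 2-methylphenyl group. Also open, from the compounds shown here alone, are how a piperidine, morpholine or piperazine ring without the methyl group would compare at the chain end, and whether a longer chain than 3-(pyrrolidin-1-yl)propyl would shift the number.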